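Swapping a piperidine amide for a sulfoxide-bearing ring

This account rests on a few compounds, and the source may have more. Where it says the series, first, only, none or still open, it means among the compounds named here.

Measured so far:
- compound 1, `CC(C)(C)c1cc(NC(=O)[C@@H]2CCCCN2C(=O)C2CCS(=O)(=O)CC2)no1`, gives 67 ug/mL in a physicochemical assay for solubility, read by HPLC, at pH 6.8; on this read-out lower numbers stand for lower solubility and higher numbers for higher solubility
- compound 2, `CC(C)(C)c1cc(NC(=O)[C@@H]2CCCCN2C(=O)CC2CCOCC2)no1`, gives 52 ug/mL in this assay
- compound 3, `CC(C)(C)c1cc(NC(=O)[C@@H]2CCCCN2C(=O)N2CCCCC2)no1`, gives 49 ug/mL in this assay

All three share one core and differ only in the group on the carbonyl carbon attached to the ring nitrogen. Compound 3 cannot be told apart from the others: a 1.4-fold lower number from compound 1 to compound 3 (0.14 log units; within the scatter) and a 1.1-fold lower number from compound 2 to compound 3 (0.03 log units; within the scatter), and likewise a 1.3-fold lower number from compound 1 to compound 2 (0.11 log units; within the scatter). Compound 4, `CC(C)(C)c1cc(NC(=O)[C@@H]2CCCCN2C(=O)N2CC[S+]([O-])CC2)no1`, continues this series: a group of 7 heavy atoms (4 carbon, 1 nitrogen, 1 oxygen, 1 sulfur; one six-membered non-aromatic ring with 2 hetero atoms) in place of a group of 6 heavy atoms (5 carbon, 1 nitrogen; one six-membered non-aromatic ring with 1 hetero atom), on a carbonyl carbon. The step from compound 1 to compound 3 is the closest comparison, since it also exchanges a six-membered ring holding a sulfur with two oxygens for a piperidin-1-yl, and it stayed within the scatter. The other two steps were equally small. No step beyond the scatter is therefore expected in this assay, though a small rise toward the number of compound 1 seems the likelier side. Compound 4 is estimated at 65 ug/mL, between 35 ug/mL and 120 ug/mL, which means an expected step of a 1.3-fold higher number from compound 3 to compound 4 (0.12 log units; within the scatter).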

Compound 4, solubility: 68 ug/mL
Estimate against measurement, compound 4: 1.0-fold (0.02 log units) below, and the stated range covers the measured number.
By their numbers in this assay, from the lowest: compounds 3, 2, 1 and 4 (each within the scatter of the next).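

Putting this ring with its sulfur and oxygen on the carbonyl carbon in place of piperidin-1-yl gives a 1.4-fold higher number from compound 3 to compound 4 (0.14 log units; within the scatter) in this assay and so does not separate the two groups. The new group also cannot be told apart from the other two, with a 1.3-fold higher number from compound 2 to compound 4 (0.12 log units; within the scatter) and a 1.0-fold higher number from compound 1 to compound 4 (0.01 log units; within the scatter) on the same read-out, so four groups on this carbonyl carbon, joined through either ring nitrogen or carbon, now read alike. No accompanying measurement explains why these numbers sit so close together.

The compounds shown leave open whether any group at this position can move the number beyond the scatter, for example piperazin-1-yl or a longer chain ending in a carboxylic acid. They also leave open whether this swap would read the same on a different core, as all four compounds share one.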